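This account rests on a few compounds, and the source may have more. Where it says the series, first, only, none or still open, it means among the compounds named here.

Measured in a functional assay on CCRF-CEM cells (Homo sapiens) for antiproliferative activity, with a stated time of 72 h; on this read-out higher numbers stand for weaker inhibition and lower numbers for stronger inhibition:
- Compound 1 `OC[C@H]1O[C@@H](n2cnc3c(NCc4ccc(F)cc4)ncnc32)[C@H](O)[C@@H]1O`: 1250 nM
- Compound 2 `OC[C@H]1O[C@@H](n2cnc3c(NCc4ccc(Cl)c(Cl)c4)ncnc32)[C@H](O)[C@@H]1O`: 3800 nM
- Compound 3 `OC[C@H]1O[C@@H](n2cnc3c(NCc4ccc(F)cc4F)ncnc32)[C@H](O)[C@@H]1O`: 7100 nM

Compound 3 shares the weak end of this small set with compound 2. The data show a 1.9-fold higher number from compound 2 to compound 3 (0.27 log units; within the scatter), and also a 5.7-fold higher number from compound 1 to compound 3 (0.75 log units; beyond the scatter).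

The next molecule, compound 4 `Cc1ccc(O)c(CNc2ncnc3c2ncn3[C@@H]2O[C@H](CO)[C@@H](O)[C@H]2O)c1`, keeps the shared core and has 2-hydroxy-5-methylphenyl in place of 2,4-difluorophenyl on a saturated chain carbon bound to a nitrogen on an aromatic ring.

All three measured steps change this same group, so all of them bear on the question. The third is a 3.0-fold higher number from compound 1 to compound 2 (0.48 log units; beyond the scatter). Each is modest or lies within the scatter, so swaps of this group have so far moved the number only moderately. For the measured compounds named here, none of the measured compounds carries a hydroxy or a methyl group, so the data give no direct guide to this particular swap.

A modest step at most is therefore expected, and the direction is uncertain. The expectation leans towards a lower number, as compound 3, at 7100 nM, starts from the weak end of the set. The estimated move is a 2.0-fold lower number from compound 3 to compound 4 (0.31 log units; beyond the scatter). For compound 4 the expected value is 3500 nM, with an estimated range from 900 nM to 14000 nM.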

Compound 4, half-maximal inhibitory concentration: 1900 nM
Compound 4: middle estimate off by 1.8-fold (0.27 log units), on the high side; low and high end bracket the measured number.
By their numbers in this assay, from the lowest: compounds 1, 4, 2 and 3 (each within the scatter of the next, the first and the last beyond it).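

In this assay, for the compounds shown here, the 2-hydroxy-5-methylphenyl group is the first group in this set to carry a hydroxy and a methyl group, and exchanging 2,4-difluorophenyl for it gives a 3.7-fold lower number from compound 3 to compound 4 (0.57 log units; beyond the scatter). The same group set against the other two aryl groups gives a 2.0-fold lower number from compound 2 to compound 4 (0.30 log units; within the scatter) and a 1.5-fold higher number from compound 1 to compound 4 (0.18 log units; within the scatter), both within the scatter, so a ring with no halogen at all reads the same as the halogenated rings of compound 1 and compound 2, while compound 3 is the one that stands apart from it. Nothing shown here accounts for the size of this step.

The compounds shown leave open whether the hydroxy group, the methyl group or the loss of the two fluorines drives the step, since all these changes arrive together, and a ring carrying only the hydroxy group or only the methyl group would separate them. Also open, on these data alone, is how an amine or a carboxylic acid on this ring, or a longer chain in place of the benzyl unit, would read at this place.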